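Bromo for chloro on the aromatic carbon of compound 3

The compounds below may be only part of what the source reports. "The series", "measured", "known", "first", "only" and "open" are said of these compounds alone.

Of the three measured compounds, compound 3 `O=C(NCCCCc1ccccc1)n1c(=O)oc2cc(Cl)ccc21` gives the smallest number in an assay on HEK293 cells for inhibition of acid ceramidase (Homo sapiens), with a stated time of 10 min (on this read-out lower numbers stand for stronger inhibition and higher numbers for weaker inhibition), 33 nM, although its gap to compound 1 lies within the scatter. Compound 1 `O=C(NCCCCc1ccccc1)n1c(=O)oc2ccccc21` gives 64 nM and compound 2 `O=C(NCCCCc1ccccc1)n1c(=O)oc2cc(-c3ccc(F)cc3)ccc21` gives 79 nM. The step of a 1.9-fold lower number from compound 1 to compound 3 (0.29 log units; within the scatter) stays within the scatter; the step of a 2.4-fold lower number from compound 2 to compound 3 (0.38 log units; beyond the scatter) goes beyond it, but only modestly. Compound 4 `O=C(NCCCCc1ccccc1)n1c(=O)oc2cc(Br)ccc21` differs from compound 3 by bromo in place of chloro on an aromatic carbon. Among the measured compounds shown here, no measured step exchanges one halogen for another; the two steps that end at compound 3 both replace a group at the same aromatic carbon, so they bear on the place of the change rather than on its size. A shift no larger than the scatter is therefore expected, a 1.1-fold lower number from compound 3 to compound 4 (0.04 log units; within the scatter). For compound 4 the expected value is 30 nM, with a range from 15 nM to 60 nM.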

Compound 4, half-maximal inhibitory concentration in the acid ceramidase assay: 31 nM
Beside the measured number, compound 4's estimate is 1.0-fold (0.01 log units) below it; measured number inside the range.
By their numbers in the acid ceramidase assay, from the lowest: compounds 4, 3, 1 and 2 (each within the scatter of the next, the first and the last beyond it).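

In the acid ceramidase assay this aromatic carbon takes bromo as it takes chloro, a 1.1-fold lower number from compound 3 to compound 4 (0.03 log units; within the scatter). In the acid ceramidase assay bromo clears the scatter, though only modestly, against hydrogen, a 2.1-fold lower number from compound 1 to compound 4 (0.31 log units; beyond the scatter), and against 4-fluorophenyl, a 2.5-fold lower number from compound 2 to compound 4 (0.41 log units; beyond the scatter), whereas chloro against hydrogen stayed within it. In a physicochemical assay for metabolic stability, read by HPLC, in phosphate buffer, at pH 7.4, tested at 10 uM (on this read-out higher numbers stand for a longer-lived compound and lower numbers for a shorter-lived compound), compound 3 gives 0.967 h and compound 4 gives 0.4 h. The exchange of halogen separates the two compounds only in the physicochemical assay: the measured half-life of compound 3, 0.967 h, and of compound 4, 0.4 h, a 2.4-fold lower number (0.38 log units; beyond the scatter)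

Going by these compounds, how iodo, an amine or a carboxylic acid on this aromatic carbon would read in the acid ceramidase assay and in the physicochemical assay stays open.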